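The source may report more compounds than this note shows. Statements on the series, on what has been measured and on what is new or still open speak of the compounds shown alone.

Compound 1 `COc1ccc(-c2nc(C)c(C(=O)CSc3nc(-c4ccc(Cl)cc4)c(C#N)c(=O)[nH]3)s2)cc1` gives 92.7% in a functional assay on U-87MG ATCC cells for antiproliferative activity against U-87 MG (Homo sapiens), read by MTT assay, with a stated time of 48 h, tested at 10 uM (a higher number here means a weaker effect of the compound at the concentration tested, a lower number a stronger effect), and stands first of the two numbers shown, though compound 2 `Cc1nc(-c2ccccc2)sc1C(=O)CSc1nc(-c2ccc(Cl)cc2)c(C#N)c(=O)[nH]1` gives 85.2% and the step of a number 7.5 percentage points lower from compound 1 to compound 2 (within the scatter) lies within the scatter. Compound 3 `COc1ccc(-c2nc(C)c(C(=O)CSc3nc(-c4cccc(Cl)c4)c(C#N)c(=O)[nH]3)s2)cc1` differs from compound 1 by 3-chlorophenyl in place of 4-chlorophenyl on an aromatic carbon. For the measured compounds named here, no measured step bears on this change; the only step at hand, hydrogen in place of methoxy, concerns another part of the shared core and was itself within the scatter. The expected step is therefore a number 2.7 percentage points lower from compound 1 to compound 3 (within the scatter), nothing beyond the scatter. Compound 3 is estimated at 90%, between 75% and 100%.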

Compound 3, a percentage reported as activity, at one concentration (the size of the read-out at that concentration, not a potency): 90.6%
Beside the measured number, compound 3's estimate is 0.6 percentage points below it; the range from low to high includes it.
By their numbers in this assay, from the lowest: compounds 2, 3 and 1 (each within the scatter of the next).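

The change to 3-chlorophenyl in place of 4-chlorophenyl gives a number 2.1 percentage points lower from compound 1 to compound 3 (within the scatter) in this assay. For the compounds shown here, this is the first reading at this position, ortho to a cyano group, and moving the chlorine within the chlorophenyl group leaves the read-out within the scatter. No measurement at hand offers a reason for this outcome. From the compounds shown here alone, whether an amine or a carboxylic acid in place of the chlorophenyl group would shift the read-out beyond the scatter stays open. So does whether any change at this position can do so.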